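The compounds below may be only part of what the source reports. "The series", "measured", "known", "first", "only" and "open" are said of these compounds alone.

Measured so far in a functional assay on MCF7 cells (Homo sapiens) for inhibition, read by resazurin assay, with a stated time of 72 h; a higher number here means a weaker inhibitor, a lower number a stronger inhibitor:
compound 1 `CCSc1ccc(C2C(Oc3ccccc3)C(=O)N2c2cc(OC)c(OC)c(OC)c2)cc1` gives 210 nM
compound 2 `COc1cc(N2C(=O)C(Oc3ccccc3)C2c2ccc(SC)cc2)cc(OC)c1OC` gives 152 nM
compound 3 `COc1cc(N2C(=O)C(C3CC3)C2c2ccc(SC)cc2)cc(OC)c1OC` gives 131 nM

Compound 2 and compound 1 share a core and differ only by methyl in place of hydrogen on a saturated chain carbon bound to a sulfur; that change gave a 1.4-fold higher number from compound 2 to compound 1 (0.14 log units; within the scatter). The cores of compound 2 and compound 3 differ by cyclopropyl in place of phenoxy on a saturated ring carbon, a change that gave a 1.2-fold lower number from compound 2 to compound 3 (0.06 log units; within the scatter). Compound 4 `CCSc1ccc(C2C(C3CC3)C(=O)N2c2cc(OC)c(OC)c(OC)c2)cc1` is not yet measured. It differs from compound 3 by methyl in place of hydrogen on a saturated chain carbon bound to a sulfur; the place is described in the same words as for the earlier pair, so this is the same change made on the core of compound 3. The expectation for it rests on the earlier step of a 1.4-fold higher number from compound 2 to compound 1 (0.14 log units; within the scatter). On that basis compound 4 is expected to show a 1.3-fold higher number from compound 3 to compound 4 (0.13 log units; within the scatter). The estimate for compound 4 in this assay is 175 nM, expected to lie between 90 nM and 340 nM.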

Compound 4, half-maximal inhibitory concentration: 606 nM
Estimate against measurement, compound 4: 3.5-fold (0.54 log units) below, and the stated range ends below it.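

In this assay, methyl in place of hydrogen on a saturated chain carbon bound to a sulfur did not carry over unchanged from one core to the other, giving a 4.6-fold higher number from compound 3 to compound 4 (0.67 log units; beyond the scatter): the same change on two cores in this assay, a 1.4-fold higher number (0.14 log units; within the scatter) from compound 2 to compound 1 and a 4.6-fold higher number (0.67 log units; beyond the scatter) from compound 3 to compound 4, 3.3-fold (0.52 log units) apart, beyond the scatter of two such steps. Cyclopropyl in place of phenoxy on a saturated ring carbon also depended on the core, giving a 2.9-fold higher number from compound 1 to compound 4 (0.46 log units; beyond the scatter): the same change on two cores in this assay, a 1.2-fold lower number (0.06 log units; within the scatter) from compound 2 to compound 3 and a 2.9-fold higher number (0.46 log units; beyond the scatter) from compound 1 to compound 4, 3.3-fold (0.52 log units) apart, beyond the scatter of two such steps. The two changes therefore do not add up across these four compounds, but the data do not show how either change would behave on any further core.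

Open, going by these compounds, is whether the higher number of compound 4 persists with propylsulfanyl in place of ethylsulfanyl, or with an amine in place of cyclopropyl on a saturated ring carbon.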